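Chloro next to the ring nitrogen: cytotoxicity expectation

This account rests on a few compounds, and the source may have more. Where it says the series, first, only, none or still open, it means among the compounds named here.

Compound 1 `COc1cccc(S(=O)(=O)/C=C/c2ccccn2)c1` and compound 2 `COc1cccc(S(=O)(=O)/C=C/c2cccnc2)c1` share a core and differ only in the pyridyl attachment. In an ADME assay on BV-2 cells (Mus musculus) for cytotoxicity, with a stated time of 24 h, tested at 10 uM (a higher number here means a weaker effect of the compound at the concentration tested, a lower number a stronger effect), compound 1 gives 100%, and compound 2 gives 100%. The step of no change at the digits printed from compound 1 to compound 2 (within the scatter) stays within the scatter, so compound 2 stands level with compound 1 at the top of the range. Compound 3 `COc1cccc(S(=O)(=O)/C=C/c2cccnc2Cl)c1` is not yet measured; it differs from compound 2 by chloro in place of hydrogen on an aromatic carbon, the new group sitting next to the ring nitrogen, ortho to a large group. Among the compounds with values here, no measured step introduces chloro, so only the flat step from compound 1 to compound 2 bears on it, and that step shows no movement. Compound 3 is therefore expected to hold at 100%, between 85% and 105%, a step of no change at the digits printed from compound 2 to compound 3 (within the scatter) that is expected to stay within the scatter.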

Compound 3, a percentage reported as activity, at one concentration (the size of the read-out at that concentration, not a potency): 100%
Compound 3: middle estimate and measured number agree at the digits printed; the measured number falls inside the stated range.
By their numbers in this assay, from the lowest: compounds 1, 2 and 3 (each within the scatter of the next).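

In this assay, chloro in place of hydrogen on an aromatic carbon, next to the ring nitrogen and ortho to a large group, brings no change at the digits printed from compound 2 to compound 3 (within the scatter). The earlier pair differed only in the pyridyl attachment, so this is the only step shown that adds a heavy atom to that ring, and at this position the chlorine leaves the read-out level with the other two compounds. No evidence on why the read-out stays level accompanies this result.

Going by these compounds, whether an amine or a nitrile at the same place would also leave the read-out level remains open, as does the effect of chloro on another carbon of that ring. The compounds shown also do not tell whether an ethoxy group in place of the methoxy group on the shared core would keep this level.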